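The source may report more compounds than this note shows. Statements on the series, on what has been measured and on what is new or still open speak of the compounds shown alone.

Series around compound 1 `CNC1=C(Cl)C(=O)c2ncccc2C1=O`. In a functional assay on cells (Neutrophil, Homo sapiens) for inhibition, read by WST assay, with a stated time of 20 min (on this read-out higher numbers stand for weaker inhibition and lower numbers for stronger inhibition), compound 1 gives 78900 nM. For compound 2 `NC1=C(Cl)C(=O)c2ncccc2C1=O` this assay reports only a limit, > 200000 nM. For compound 3 `CNC1=C([S+](C)[O-])C(=O)c2ncccc2C1=O` this assay likewise reports a limit, > 200000 nM. Compound 2 therefore stands at the limit of > 200000 nM in this assay, at which 2 of the 3 values shown sit, without a number of its own. Compound 4 `CSC1=C(N)C(=O)c2cccnc2C1=O` differs from compound 2 by methylsulfanyl in place of chloro on a double-bonded ring carbon. Within the data shown here, no measured step repeats this change exactly. The nearest is an at least 2.5-fold higher number from compound 1 to compound 3 (0.40 log units; beyond the scatter), a sulfur-bearing group entering for chlorine; the other is an at least 2.5-fold higher number from compound 1 to compound 2 (0.40 log units; beyond the scatter). Both measured steps run toward weaker inhibition and compound 2 already sits at the limit. Compound 4 is expected to remain there, with a step that the limit leaves unreadable from compound 2 to compound 4. The estimate for compound 4 is 300000 nM, between 100000 nM and 1000000 nM, most likely reported again only as a limit.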

Compound 4, half-maximal inhibitory concentration: > 150000 nM
Compound 4 was reported as a limit; the forecaster's own chance of this, stated with the estimate: 80%; the middle value does not contradict the limit.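

Compound 2 and compound 4 are both reported only as limits in this assay, and the step between them cannot be read. The compounds shown leave open whether methylsulfanyl in place of chloro changes inhibition at all.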